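This account rests on a few compounds, and the source may have more. Where it says the series, first, only, none or still open, it means among the compounds named here.

Measured so far: compound 1 `CN(C)CCC1CCCC(c2ccccc2)C1` gives 115 nM; compound 2 `c1ccc(CNCC[C@H]2CCC[C@@H](c3ccccc3)C2)cc1` gives 47 nM; compound 3 `c1ccc([C@H]2CCC[C@@H](CCN3CCN(c4ccccc4)CC3)C2)cc1` gives 118 nM, all in an assay on membranes from liver for displacement of a labelled ligand from Sigma intracellular receptor 2 (Rattus norvegicus), read by scintillation counting, with a stated time of 120 min; a lower number here means a stronger inhibitor, a higher number a weaker inhibitor.

Among these three numbers compound 1 stands second highest. Its nearest neighbour is compound 3, whose value lies within the scatter of that of compound 1, so no order between the two can be read. Compound 2 gives the lowest number of the three, and its gap to compound 1 lies beyond the scatter.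

Compound 4 `CN(C)CC[C@@H]1CCC[C@H](c2ccccc2)C1` differs from compound 1 only in how its stereocentres are drawn: the two compounds have the same atoms and bonds; at least one stereo element is drawn with a configuration in one of them and without one in the other: 2 of 2 stereo elements differ; a stereocentre at a saturated ring carbon is drawn without a configuration in compound 1 and R in compound 4; a stereocentre at a saturated ring carbon is drawn without a configuration in compound 1 and S in compound 4. Within the data shown here, no step between two measured compounds mirrors this change, so there is nothing in the set to fix its size or direction. A change in drawn configuration alone, with the same atoms and bonds, is expected to move this assay by a modest amount at most, and the direction cannot be anchored in the data. Compound 4 is therefore estimated at 80 nM, between 30 nM and 300 nM, which means an expected step of a 1.4-fold lower number from compound 1 to compound 4 (0.16 log units; within the scatter) that is small and may well sit within the scatter.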

Compound 4, inhibition constant: 76 nM
For compound 4 the middle estimate is 1.1-fold (0.02 log units) above the measured one; measured number inside the range.
By their numbers in this assay, from the lowest: compounds 2, 4, 1 and 3 (each within the scatter of the next, the first and the last beyond it).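

Drawing both ring stereocentres with a defined configuration barely registers in this assay: the result is a 1.5-fold lower number from compound 1 to compound 4 (0.18 log units; within the scatter). Among these compounds, this is the first step in the set between two compounds that differ in one place, and it shows that, for this dimethylamino compound, the defined form of compound 4 cannot be told apart from the form drawn without configuration in compound 1. The comparison rests on a single difference: the fact that one of compounds 1 and 4 is drawn with a defined configuration and the other without, at the place where they differ

The compounds shown leave open how any other configuration at these two ring carbons would read, including the mirror image of compound 4. Also open, from the compounds shown here alone, is what a morpholine in place of the dimethylamino group, or a longer chain leading to the amine, would do in the configuration of compound 4.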